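A few compounds are considered here, and "the series" means these few. Any claim that something is new, unique, unknown or untested is made for them only; others in the source may bear on it.

Measured in an ADME assay (liver) for metabolic stability, with Liver microsome (Homo sapiens) as the target, using microsomes; on this read-out higher numbers stand for a longer-lived compound and lower numbers for a shorter-lived compound:

Compound 1 `CCc1nc2cc(Cl)ccn2c1C(=O)NCc1ccc(-c2ccc(Cl)cc2)cc1`: > 2 h, a limit
Compound 2 `CCc1nc2cc(Cl)ccn2c1C(=O)NCc1ccc(-c2ccc(C(=O)O)cc2)cc1`: > 2 h, a limit
Compound 3 `CCc1nc2cc(Cl)ccn2c1C(=O)NCc1ccc(N2CCCCCC2)cc1`: 0.0483 h

Compound 3 alone gives a number, 0.0483 h. The other two values are limits. Compound 4 `CCc1nc2cc(Cl)ccn2c1C(=O)NCc1ccc(N2CCN(C(C)C)CC2)cc1` has 4-isopropylpiperazin-1-yl in place of azepan-1-yl on an aromatic carbon. Two large measured steps bear on this place: an at least 41-fold lower number from compound 1 to compound 3 (1.61 log units; beyond the scatter), and an at least 41-fold lower number from compound 2 to compound 3 (1.61 log units; beyond the scatter). Neither exchanges one non-aromatic ring for another, so neither sets the size here. Compound 3, at 0.0483 h, carries a non-aromatic ring there, and so does the entering group. The expected change in this assay is therefore small and upward: a 2.5-fold higher number from compound 3 to compound 4 (0.40 log units; beyond the scatter). Compound 4 is estimated at 0.12 h, with an expected range of 0.04 h to 0.6 h.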

Compound 4, half-life: > 2 h
Compound 4 was reported as a limit; the forecaster's own chance of this, stated with the estimate: 5%; at least 16-fold (1.22 log units) between middle value and limit.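

In this assay, swapping one non-aromatic ring for another on this aromatic carbon proves to be no small change: 4-isopropylpiperazin-1-yl in place of azepan-1-yl gives an at least 41-fold higher number from compound 3 to compound 4 (1.61 log units; beyond the scatter). So a non-aromatic ring here does not by itself go with the short-lived result of compound 3. Compound 4 is reported only as a limit, the same one that applies to most of the series: the limit of > 2 h in this assay, at which 3 of the 4 values shown sit.

The steps from compound 1 and from compound 2 to compound 4 cannot be read, since both ends are limits. Going by these compounds, whether the second ring nitrogen or the isopropyl group carries the step stays open, and a plain piperazin-1-yl or a morpholin-4-yl at this place would be needed to separate them.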